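Removing a Chloro Group from a Dihydrofolate Reductase Inhibitor

The source may report more compounds than this note shows. Statements on the series, on what has been measured and on what is new or still open speak of the compounds shown alone.

Compound 1 `NC1=NC2(CCOCC2)N(OCCCOc2cccc(Cl)c2)C(N)=N1` is the starting point of this step. In an assay on isolated protein for inhibition of Dihydrofolate reductase (Homo sapiens), read by spectrophotometry, using NADPH, with stated times of 5 s and 6 min (a higher number here means a weaker inhibitor, a lower number a stronger inhibitor), compound 1 gives "not determined" (no result reported), so no single number stands for it, and its near relative compound 2 `NC1=NC2(CCOCC2)N(OCCCOc2cccc(Cl)c2Cl)C(N)=N1` likewise gives "not determined" (no result reported) in this assay. Within the data shown here, the only number in the set belongs to compound 3 `COc1ccc(OCCCON2C(N)=NC(N)=NC23CCOCC3)cc1`, which in this assay gives 11.1 nM. Compound 4 `NC1=NC2(CCOCC2)N(OCCCOc2ccccc2)C(N)=N1` has not yet been measured. It differs from compound 1 in one place: hydrogen in place of chloro on an aromatic carbon. Among the measured compounds shown here, with no number for compound 1, no measured step can be drawn for this change, and the size of the step in this assay cannot be read from the data; the expectation is a modest shift, if any, and not one clearly beyond the scatter. For the measured compounds named here, the only anchor is compound 3, which carries a methoxy group on the same ring and whose value of 11.1 nM in this assay suggests that this family stays in the low range. Compound 4 is therefore estimated at 15 nM in this assay, with a range from 4 nM to 60 nM.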

Compound 4, half-maximal inhibitory concentration: 86.1 nM
The estimate for compound 4 lay 5.7-fold (0.76 log units) below the measured number; measured number outside the range, above it.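

The result gives this family its first measured step in this assay: taking the methoxy group off the ring gives a 7.8-fold higher number from compound 3 to compound 4 (0.89 log units; beyond the scatter) and so the change lies beyond the usual scatter. It shows that the ring without any substituent, as in compound 4, does not match the methoxy-bearing ring of compound 3 in this assay, and that a group on this ring can move the number by a clear margin. No accompanying measurement bears on why the number moves.

Among these compounds, the steps that would join compound 1 or compound 2 to compound 4 cannot be read, so what chloro does on this ring, alone or as the second chloro of compound 2, stays unknown, and the single comparison between compound 3 and compound 4 cannot be extended to it. Also open, going by these compounds, is whether an amine or a carboxylic acid on the same ring, or a longer chain in place of the one that links the ring to the shared core, would bring the number nearer to that of compound 3 or take it further away.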